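Lengthening the Amide Chain on a Thioglycoside Scaffold

This account rests on a few compounds, and the source may have more. Where it says the series, first, only, none or still open, it means among the compounds named here.

Compound 1 `CCCCCCCC(=O)Nc1nnc(S[C@@H]2O[C@H](CO)[C@H](O)[C@H](O)[C@H]2O)s1` and compound 2 `CCCCCCCC/C=C\CCCCCCCCCCCC(=O)Nc1nnc(S[C@@H]2O[C@H](COC(C)=O)[C@H](OC(C)=O)[C@H](OC(C)=O)[C@H]2OC(C)=O)s1` share a thiadiazole core linked to a sugar through sulfur. In a functional assay on HeLa cells (Homo sapiens) for cytotoxicity, read by MTT assay, with a stated time of 24 h (on this read-out lower numbers stand for stronger inhibition and higher numbers for weaker inhibition), compound 1 gives 50800 nM, the smaller of the two numbers shown, while compound 2 gives 58500 nM, a gap that lies within the usual scatter. Compound 3 `CCCCCCCCCCCCCCCC(=O)Nc1nnc(S[C@@H]2O[C@H](CO)[C@H](O)[C@H](O)[C@H]2O)s1` differs from compound 1 by octyl in place of hydrogen on a saturated chain carbon, seven bonds along the chain from a carbonyl carbon. Among the compounds with values here, with no measured step of this kind to draw on, and with the long-chain compound 2 giving a number close to that of compound 1, the step of a 1.1-fold lower number from compound 1 to compound 3 (0.02 log units; within the scatter) is expected to stay within the scatter. Compound 3 is thus estimated at 48000 nM, with a likely range of 20000 nM to 115000 nM.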

Compound 3, half-maximal inhibitory concentration: 14200 nM
Compound 3: middle estimate off by 3.4-fold (0.53 log units), on the high side, outside the stated range (below it).
By their numbers in this assay, from the lowest: compound 3; then compounds 1 and 2 (each within the scatter of the next).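

Swapping hydrogen for octyl on a saturated chain carbon, seven bonds along the chain from a carbonyl carbon, gives a 3.6-fold lower number from compound 1 to compound 3 (0.55 log units; beyond the scatter) in this assay with nothing else in the molecule changed. This position therefore accepts the added carbons, and the change in chain length alone moves the number beyond the scatter, if only modestly.

On these data alone, whether a longer chain would lower the number further, or a chain ending in a carboxylic acid or an amine would keep the step, remains open. Nothing shown here explains why the step occurs.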